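This account rests on a few compounds, and the source may have more. Where it says the series, first, only, none or still open, it means among the compounds named here.

In a functional assay on HL-60 cells (Homo sapiens) for cytotoxicity, read by luminescence and CellTiter-Glo, with a stated time of 3 days (a lower number here means a stronger inhibitor, a higher number a weaker inhibitor), three compounds have been measured so far. Compound 1 (`N#Cc1ccc(NC(=O)c2ccc(C(F)(F)F)cc2O)cc1`) gives 1030 nM, compound 2 (`O=C(Nc1ccc(C(F)(F)F)cc1)c1ccc(F)cc1O`) gives 680 nM, and compound 3 (`N#Cc1ccc(NC(=O)c2ccccc2O)cc1`) gives 4620 nM, the highest number of the three. Compound 4 (`N#Cc1ccc(NC(=O)c2ccc(F)cc2O)cc1`) has not yet been measured. It departs from compound 3 by a single change: fluoro in place of hydrogen on an aromatic carbon. In words, this is fluoro in place of hydrogen on an aromatic carbon.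

Going by the values given here, one measured step bears directly on this change: a 4.5-fold higher number from compound 1 to compound 3 (0.65 log units; beyond the scatter), where hydrogen replaces trifluoromethyl on an aromatic carbon. That step is modest but beyond the scatter. Read in reverse, it suggests that a group entering on that ring could lower the number, although fluoro is not trifluoromethyl and the effect may carry over only in part. Compound 2 also bears fluoro and stands at 680 nM, but it has no measured partner that lacks fluoro, so the contribution of fluoro alone remains unmeasured.

A lower number is therefore expected, by a smaller step than the measured one. The expected change is a 2.1-fold lower number from compound 3 to compound 4 (0.32 log units; beyond the scatter). In this assay, the estimate for compound 4 is 2200 nM, with an expected range of 1000 nM to 4800 nM.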

Compound 4, half-maximal inhibitory concentration: 1380 nM
Compound 4: the middle estimate sits 1.6-fold (0.20 log units) above what was measured; the range from low to high includes it.
By their numbers in this assay, from the lowest: compounds 2, 1 and 4 (each within the scatter of the next, the first and the last beyond it); then compound 3.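

In this assay, fluoro meta to a hydroxy group and para to a large group gives a 3.3-fold lower number from compound 3 to compound 4 (0.52 log units; beyond the scatter), so the contribution of fluoro alone at this position can now be read, which compound 2 could not provide. The comparison with trifluoromethyl at the same position gives a 1.3-fold higher number from compound 1 to compound 4 (0.13 log units; within the scatter), which lies within the scatter; the two groups cannot be told apart here, although each stands beyond the scatter from hydrogen, as a 4.5-fold higher number from compound 1 to compound 3 (0.65 log units; beyond the scatter) shows for trifluoromethyl. With fluoro held constant, cyano in place of trifluoromethyl on an aromatic carbon elsewhere in the molecule gives a 2.0-fold higher number from compound 2 to compound 4 (0.31 log units; beyond the scatter), a modest step beyond the scatter, so the result also depends on the group at that second place.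

Nothing in the data shown gives a reason for any of these steps. As far as these compounds go, it remains open whether the lower number at this position would hold with an amine, a methoxy group or a carboxylic acid there, or whether it is confined to fluoro and trifluoromethyl.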